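Oxolan-3-yl to oxolan-2-yl: expected effect on potency

A few compounds are considered here, and "the series" means these few. Any claim that something is new, unique, unknown or untested is made for them only; others in the source may bear on it.

For the measured compounds named here, in a functional assay on KARPAS-422 cells (Homo sapiens) for antiproliferative activity, read by resazurin assay, with a stated time of 72 h (a lower number here means a stronger inhibitor, a higher number a weaker inhibitor), compound 1 (`Cc1cc(C)c(CN2CCc3c(Cl)cc([C@H](CO)[C@H]4CCOC4)c(Cl)c3C2=O)c(=O)[nH]1`) gives 15 nM as its only single number, and one further entry for it carries no single number. Going by the values given here, the only other reference is compound 2 (`COC(c1cc(Cl)c2c(c1Cl)C(=O)N(Cc1c(C)cc(C)[nH]c1=O)CC2)C1CCS(=O)(=O)CC1`), whose entries of 970 nM; 24 nM (2 entries) lie far apart. Compound 3 (`Cc1cc(C)c(CN2CCc3c(Cl)cc([C@H](CO)[C@@H]4CCCO4)c(Cl)c3C2=O)c(=O)[nH]1`) has the same atoms as compound 1, joined differently (oxolan-2-yl in place of oxolan-3-yl on a saturated chain carbon bound to an aromatic carbon and a saturated chain carbon): oxolan-2-yl stands in place of oxolan-3-yl on a saturated chain carbon bound to an aromatic carbon and a saturated chain carbon. Among the compounds with values here, no measured pair isolates this change, so its size cannot be read from the data. The working expectation in this assay is a modest loss of potency, possibly no larger than the scatter. This swap is expected to give a 2.3-fold higher number from compound 1 to compound 3 (0.37 log units; beyond the scatter). The estimated range stays wide because the several entries of compound 2 in this assay, 970 nM; 24 nM (2 entries) leave even compound 2 uncertain by a large margin. Compound 3 is expected at 35 nM (estimated range 8 nM to 150 nM).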

Compound 3, half-maximal inhibitory concentration: 57 nM
For compound 3 the middle estimate is 1.6-fold (0.21 log units) below the measured one; the measured number falls inside the stated range.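

In this assay, for the compounds shown here, the swap of oxolan-3-yl for oxolan-2-yl gives a 3.8-fold higher number from compound 1 to compound 3 (0.58 log units; beyond the scatter), the first measured change that isolates this place, on a saturated chain carbon bound to an aromatic carbon and a saturated chain carbon. The two groups match in every count computed for them, including heavy atoms, hydrogen-bond donors and acceptors, and net charge, so potency at this place depends on more than those counts, though the loss is modest and compound 3 still gives 57 nM. Nothing among the measurements shown explains this step.

Going by these compounds, each of the two oxolane groups appears with a single defined stereocentre, so it remains open whether the step holds for the opposite configuration of either ring or of the carbon that carries it. Also open, on these data alone, is how this place would respond to a group of another kind, such as an amine, a carboxylic acid or a longer open chain, as compound 2 differs from compound 1 in more than one place and offers no clean comparison.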